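Phenyl for ethyl on the chain carbon of compound 3

The compounds below may be only part of what the source reports. "The series", "measured", "known", "first", "only" and "open" are said of these compounds alone.

Of the compounds shown here, three have been measured in an assay on CHO-K1 cells for binding affinity to muscarinic acetylcholine receptor M5 (Homo sapiens); on this read-out lower numbers stand for stronger inhibition and higher numbers for weaker inhibition. Compound 1 `CSc1ccc2c(c1)C(C(C)c1ccccn1)=C(CCN(C)C)C2` gives 3240 nM, compound 2 `CCC(C1=C(CCN(C)C)Cc2cc(Cl)ccc21)c1ccccn1` gives 776 nM, and compound 3 `CCC(C1=C(CCN(C)C)Cc2ccccc21)c1ccccn1` gives 676 nM. Compound 3 has the lowest number of the three; its nearest neighbour is compound 2, and the step of a 1.1-fold lower number from compound 2 to compound 3 (0.06 log units; within the scatter) for hydrogen in place of chloro on an aromatic carbon lies within the scatter, so the two are not distinguished. Compound 1, which carries methyl rather than ethyl on the chain carbon and methylthio on the ring, stands clearly higher, but two changes separate it from compound 3, so no single step can be read from that pair.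

Compound 4 `CN(C)CCC1=C(C(c2ccccc2)c2ccccn2)c2ccccc2C1` differs from compound 3 by phenyl in place of ethyl on a saturated chain carbon bound to an aromatic carbon and a double-bonded ring carbon. Among the measured compounds shown here, no measured step addresses a change at this position, and the only measured step, from compound 2 to compound 3, concerns a ring substituent and was within the scatter. The expectation for this assay is therefore uncertain; the step of a 1.4-fold lower number from compound 3 to compound 4 (0.13 log units; within the scatter) is estimated to stay near the scatter, with a wide range. For compound 4 a value of 500 nM is expected, between 150 nM and 2000 nM.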

Compound 4, inhibition constant: 66.1 nM
Compound 4: the middle estimate sits 7.6-fold (0.88 log units) above what was measured, and the stated range ends above it.
By their numbers in this assay, from the lowest: compound 4; then compounds 3 and 2 (each within the scatter of the next); then compound 1.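

In this assay the saturated chain carbon bound to an aromatic carbon and a double-bonded ring carbon turns out to be a place where one change moves the number strongly: phenyl in place of ethyl gives a 10-fold lower number from compound 3 to compound 4 (1.01 log units; beyond the scatter) as a large step beyond the scatter. The only earlier single-place step, a 1.1-fold lower number from compound 2 to compound 3 (0.06 log units; within the scatter) for hydrogen in place of chloro on an aromatic carbon, lies within the scatter, so this chain carbon is the first place in the series shown where a single change separates two compounds. Nothing on hand explains the size of the step.

Cyclohexyl or a longer chain such as butyl on the same carbon would show whether the step follows the aromatic ring of phenyl or merely the larger group in place of ethyl. Also open, on these data alone, is whether chloro on the aromatic ring of compound 4 would again leave the number within the scatter, as it did with ethyl on the chain carbon.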